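The source may hold more compounds than are shown below. What is called first, only, known or untested is meant among the compounds shown, and "the series" means these compounds.

Compound 2, `O=C(Nc1cccc(-n2cc(-c3ccncc3)c(-c3cc(O)cc(Cl)c3)n2)c1)Nc1ccc(Cl)c(C(F)(F)F)c1`, was tested in a functional assay on NCI-H460 cells (Homo sapiens) for inhibition, read by sulforhodamine B assay, with a stated time of 48 h, tested at 10 uM; a lower number here means a stronger effect, a higher number a weaker effect of the compound at the concentration tested. In that assay compound 2 gives 3.75%, the lowest of the two numbers recorded. Compound 1, `COc1cc(Cl)cc(-c2nn(-c3cccc(NC(=O)c4ccc(Cl)c(Cl)c4)c3)cc2-c2ccncc2)c1`, gives 65.2% in this assay, a number far higher than that of compound 2 and beyond the scatter; the two compounds differ in more than one place, so no single change can be read from their gap. Compound 3, `COc1cc(Cl)cc(-c2nn(-c3cccc(NC(=O)Nc4ccc(Cl)c(C(F)(F)F)c4)c3)cc2-c2ccncc2)c1`, has not yet been measured. It differs from compound 2 by one change: methyl in place of hydrogen on an oxygen on an aromatic ring. For the measured compounds named here, no measured pair shows this change alone, so its effect is unknown. The expected step is a number 11.3 percentage points higher from compound 2 to compound 3 (beyond the scatter), a small shift toward a higher number or none beyond the scatter. Compound 3 is therefore expected to give about 15% in this assay, within a range from 0% to 45%.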

Compound 3, a percentage reported as activity, at one concentration (the size of the read-out at that concentration, not a potency): 2.76%
Compound 3: middle estimate off by 12.2 percentage points, on the high side, and the stated range covers the measured number.
By their numbers in this assay, from the lowest: compounds 3 and 2 (each within the scatter of the next); then compound 1.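

Methyl in place of hydrogen on this oxygen gives a number 1 percentage points lower from compound 2 to compound 3 (within the scatter) in this assay, so at this position the read-out does not separate hydroxy from methoxy when the urea side of compound 2 is kept. For the compounds shown here, compound 3 also gives the first single-change reading of the wide gap seen earlier: (4-chloro-3-(trifluoromethyl)phenyl)amino in place of 3,4-dichlorophenyl on a carbonyl carbon gives a number 62.4 percentage points lower from compound 1 to compound 3 (beyond the scatter) and accounts for that gap with the methoxy group held constant. Nothing measured here gives a cause for either step.

Going by these compounds, it remains open whether a longer chain such as ethoxy, or an amine in place of the oxygen, would read like hydroxy and methoxy. The single concentration also leaves open whether compound 2 and compound 3 would separate at lower concentrations.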